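A few compounds are considered here, and "the series" means these few. Any claim that something is new, unique, unknown or untested is made for them only; others in the source may bear on it.

Measured in a functional assay on RKO cells (Homo sapiens) for inhibition, read by MTT assay, with a stated time of 48 h; a higher number here means a weaker inhibitor, a lower number a stronger inhibitor:
- compound 1 `COc1ccc(N(C)c2nc(C)nc3ccccc23)cc1C(=O)NCC[Se]C#N`: 1170 nM
- compound 2 `COc1ccc(N(C)c2nc(C)nc3ccccc23)cc1[Se]C`: 11 nM
- compound 3 `COc1ccc(N(C)c2nc(C)nc3ccccc23)cc1[Se]C#N`: 47 nM

Compound 3 sits in the middle of this short series. The measured steps are a 4.3-fold higher number from compound 2 to compound 3 (0.63 log units; beyond the scatter) and a 25-fold lower number from compound 1 to compound 3 (1.40 log units; beyond the scatter).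

Compound 4 `COc1ccc(N(C)c2nc(C)nc3ccccc23)cc1OCCCCC[Se]C#N` has not yet been measured. It differs from compound 3 as follows: a group of 9 heavy atoms (6 carbon, 1 nitrogen, 1 oxygen, 1 selenium; no ring) in place of a group of 3 heavy atoms (1 carbon, 1 nitrogen, 1 selenium; no ring), on an aromatic carbon. The group therefore grows on the aromatic carbon ortho to a methoxy group, and it still ends in a nitrile on selenium.

Among the compounds with values here, the closest precedent is the large step of a 25-fold lower number from compound 1 to compound 3 (1.40 log units; beyond the scatter), since compound 1 also carries a larger group ending in a nitrile on selenium. That evidence is a single pair, and the group in compound 1 contains an amide, which compound 4 lacks. A step to a higher number in this assay is therefore expected, probably smaller than that precedent but beyond the scatter. The expected step is a 6.4-fold higher number from compound 3 to compound 4 (0.81 log units; beyond the scatter). For compound 4 the estimated value is 300 nM, with an expected range from 80 nM to 1200 nM.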

Compound 4, half-maximal inhibitory concentration: 3560 nM
Compound 4: middle estimate off by 12-fold (1.07 log units), on the low side; measured number outside the range, above it.
By their numbers in this assay, from the lowest: compound 2; then compound 3; then compound 1; then compound 4.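

At this aromatic carbon, ortho to a methoxy group, a nitrile on selenium does not by itself keep the number low in this assay: the larger group gives a 76-fold higher number from compound 3 to compound 4 (1.88 log units; beyond the scatter). Set against the small methyl on selenium, the loss is greater still, at a 320-fold higher number from compound 2 to compound 4 (2.51 log units; beyond the scatter), and compound 4 is the weakest of the four. The group with an amide is not the worst case either, since the step is a 3.0-fold higher number from compound 1 to compound 4 (0.48 log units; beyond the scatter), so leaving out the amide did not restore a low number at this size of group.

Nothing measured here accounts for these rises. Going by these compounds, it remains open whether the length of the chain or its oxygen link matters more, which a shorter chain, a longer chain or an all-carbon link could separate.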